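The compounds below may be only part of what the source reports. "The series", "measured", "known", "first", "only" and "open" are said of these compounds alone.

Measured in a toxicity assay on HepG2 cells (Homo sapiens) for inhibition, read by resazurin assay, with a stated time of 24 h; a higher number here means that more compound is tolerated, a lower number that less compound is tolerated:
- compound 1 `Cn1c([N+](=O)[O-])cnc1C(=O)NCc1ccc(F)cc1`: > 100000 nM, a limit
- compound 2 `CC(NC(=O)c1ncc([N+](=O)[O-])n1C)c1ccc(F)cc1`: > 100000 nM, a limit
- compound 3 `Cn1c([N+](=O)[O-])cnc1C(=O)NC1CC1`: > 100000 nM, a limit

In this assay compound 2 stands at > 100000 nM, which is a limit and not a number. The whole set looks the same: the limit of > 100000 nM in this assay, at which 3 of the 3 values shown sit. Compound 4 `CC(NC(=O)c1ncc([N+](=O)[O-])[nH]1)c1ccc(F)cc1` carries hydrogen in place of methyl on an aromatic nitrogen. Within the data shown here, the only measured step, a step that the two limits leave unreadable from compound 1 to compound 2, changes a saturated chain carbon instead, and its size cannot be read. Among the measured compounds shown here, no measured step therefore bears directly on this change, and compound 2 with its limit remains the only guide. The expected step is a number no higher from compound 2 to compound 4 (the limit leaves the size open), none beyond the scatter. Compound 4 is estimated at 100000 nM, with an expected range from 40000 nM to 200000 nM.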

Compound 4, half-maximal cytotoxic concentration: > 100000 nM
Compound 4: a limit, no number; the forecaster's own chance of this, stated with the estimate: 80%; the middle value lies on the limit itself.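

Among these compounds, compound 2 and compound 4 both give a limit and not a number, and no step between them can be read. In this assay the compounds shown leave open the concentration at which any of them reaches half-maximal cytotoxicity.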